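The source may report more compounds than this note shows. Statements on the series, on what has been measured and on what is new or still open speak of the compounds shown alone.

Compound 1 `COc1ccc(-c2cncc(-c3cc(NCCCn4ccnc4)nc(C)n3)c2)cc1` has no result in a functional assay on Vero cells (Chlorocebus sabaeus) for cytotoxicity; a lower number here means a stronger inhibitor, a higher number a weaker inhibitor; in this assay compound 1 is given as "not determined" (no result reported), so there is no single number for where it stands. The only measured point in this assay comes from compound 2 `C[C@@H](C(=O)NCCS(=O)(=O)c1ccc(Br)cc1)S(=O)(=O)c1ccccc1`, a structure of a different kind, and in this assay compound 2 gives 48400 nM. Compound 3 `Cc1nc(NCCCn2ccnc2)cc(-c2cncc(-c3ccc(F)cc3)c2)n1` shares its core with compound 1 and differs from it in one place: fluoro in place of methoxy on an aromatic carbon, on an aromatic carbon of a six-membered aromatic ring of carbon only, para to a large group. Going by the values given here, no step between two measured compounds exists in this assay, so nothing measured tells how far such a change moves the read-out; the expected step from compound 1 to compound 3 in this assay is none beyond the usual scatter, in no particular direction. For compound 3 the half-maximal inhibitory concentration in this assay is estimated at 30000 nM, with a range from 8000 nM to 100000 nM, and a fair chance that only a limit is reported.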

Compound 3, half-maximal inhibitory concentration: 41200 nM
Compound 3: middle estimate off by 1.4-fold (0.14 log units), on the low side; the range from low to high includes it.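

In this assay, going by these compounds alone, compound 3 gives 41200 nM, but compound 1 has no single number there, so no step between compound 1 and compound 3 can be read. From the compounds shown here alone, how the change from 4-methoxyphenyl to 4-fluorophenyl moves the read-out stays open. No evidence shown here bears on this result.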